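Replacing 4-nitrophenyl with 2-bromophenyl in compound 2

The source may report more compounds than this note shows. Statements on the series, on what has been measured and on what is new or still open speak of the compounds shown alone.

- compound 1 `Cc1cc(=O)c2c(O)c(CN3CC(O)CC3C(=O)O)c(O)c([C@H]3CCN(C)C[C@H]3O)c2o1`: 25%
- compound 2 `Cc1oc2c([C@H]3CCN(C)C[C@H]3O)c(O)cc(O)c2c(=O)c1C(O)c1ccc([N+](=O)[O-])cc1`: 4%

These two compounds have been measured in a functional assay on MCF7 cells (Homo sapiens) for inhibition, read by MTT assay, with a stated time of 48 h, tested at 10 uM; a higher number here means more inhibition of growth at the concentration tested, a lower number less inhibition of growth. Of the two numbers, compound 2 holds the lower one at 4%, while compound 1 stands at 25%, and this gap lies beyond the usual scatter.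

The next compound to be tested is compound 3 `Cc1oc2c([C@H]3CCN(C)C[C@H]3O)c(O)cc(O)c2c(=O)c1C(O)c1ccccc1Br`. It keeps the shared core of compound 2 but carries 2-bromophenyl in place of 4-nitrophenyl on a saturated chain carbon bound to an aromatic carbon and an oxygen on a saturated carbon.

Within the data shown here, no measured pair shows what such a swap does in this assay, so the expectation starts from compound 2 and its low value of 4%. The expected change, a number 4 percentage points higher from compound 2 to compound 3 (within the scatter), is a small rise that stays within the scatter. For compound 3 the estimated value is 8%, with an expected range from 0% to 22%.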

Compound 3, percent growth inhibition at one concentration: 21%
Compound 3: middle estimate off by 13 percentage points, on the low side; measured number inside the range.
By their numbers in this assay, from the lowest: compound 2; then compounds 3 and 1 (each within the scatter of the next).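

In this assay, replacing 4-nitrophenyl with 2-bromophenyl gives a clean one-place comparison: the step is a number 17 percentage points higher from compound 2 to compound 3 (beyond the scatter). With the rest of compound 2 unchanged, the group on this saturated chain carbon, bound to an aromatic carbon and an oxygen on a saturated carbon, can therefore alter growth inhibition by a modest amount beyond the usual scatter, something the earlier pair could not show because its compounds differ in more than one place. This is a single step, however, and nothing measured here explains why it occurs.

The two groups differ both in the atoms attached to the ring and in the numbers in their names, so the compounds shown leave open whether the nitro group, the bromine or the placement on the ring accounts for the step. Plain phenyl and 4-bromophenyl at this carbon would help separate those possibilities, while an amine or a carboxylic acid on the ring would show whether the position accepts a wider range of groups.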